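Positional change of bromophenyl on the shared core

A few compounds are considered here, and "the series" means these few. Any claim that something is new, unique, unknown or untested is made for them only; others in the source may bear on it.

Compound 3 `COc1cc(/C=N/Nc2nc(-c3cccc(Br)c3)cs2)c(Br)c(Br)c1OC` stands at the edge of what a functional assay on HepG2 cells (Homo sapiens) for inhibition, read by MTT assay, with a stated time of 48 h (a higher number here means a weaker inhibitor, a lower number a stronger inhibitor), reports: in this assay compound 3 gives > 100000 nM, which is a limit and not a number. Compound 1 `COc1cc(/C=N/Nc2nc(-c3ccc(C(F)(F)F)cc3)cs2)c(Br)c(Br)c1OC` is likewise at a limit, since in this assay compound 1 gives > 100000 nM. Compound 2 `COc1cc(/C=N/Nc2nc(-c3ccc(F)c(F)c3)cs2)c(Br)c(Br)c1OC` gives 49700 nM in this assay. Two of the three values sit at the limit of > 100000 nM in this assay, at which 2 of the 3 values shown sit, so the measured steps are thin: an at least 2.0-fold lower number from compound 1 to compound 2 (0.30 log units; that floor lies within the scatter), an at least 2.0-fold higher number from compound 2 to compound 3 (0.30 log units; that floor lies within the scatter), and a step that the two limits leave unreadable from compound 1 to compound 3. Compound 4 `COc1cc(/C=N/Nc2nc(-c3ccc(Br)cc3)cs2)c(Br)c(Br)c1OC` differs from compound 3 by 4-bromophenyl in place of 3-bromophenyl on an aromatic carbon. Among the compounds with values here, no measured step exchanges one bromophenyl for another bromophenyl; the three steps exchange 4-(trifluoromethyl)phenyl, 3,4-difluorophenyl and 3-bromophenyl, and none of them yields a step clearly beyond the scatter. Nothing in the numbers therefore points to a step beyond the scatter in this assay, and compound 4 is expected to stay at or near the limit where compound 3 stands. The step from compound 3 to compound 4 is estimated as a number no higher from compound 3 to compound 4 (the limit leaves the size open). For compound 4 the estimate is 100000 nM, with a range from 35000 nM to 300000 nM, and it is expected that the assay again reports only a limit.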

Compound 4, half-maximal inhibitory concentration: > 100000 nM
Compound 4: no number, only a limit; the forecaster's own chance of this, stated with the estimate: 60%; the middle value sits exactly at the limit.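

In this assay compound 4 gives > 100000 nM, which is a limit and not a number. The steps to compound 4 from compound 3 and from compound 1 cannot be read, so exchanging 3-bromophenyl for 4-bromophenyl at this place gives no readable difference, and neither bromophenyl yields a number. The one readable new step is an at least 2.0-fold higher number from compound 2 to compound 4 (0.30 log units; that floor lies within the scatter), so even this comparison does not clear the scatter, and compound 2 remains the only compound in the set with a number, leaving the comparison thin: the limit of > 100000 nM in this assay, at which 3 of the 4 values shown sit.

Still open, as far as these compounds go, is whether the two bromophenyl groups differ at all in this assay, and whether any group at this place would give a step clearly beyond the scatter from 3,4-difluorophenyl. From the compounds shown here alone, it is also open whether a phenyl carrying an amine or a carboxylic acid in place of bromo would give a number rather than a limit on the shared core.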